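Hydroxypyrrolidine in Place of the Carboxylated Ring

The compounds below may be only part of what the source reports. "The series", "measured", "known", "first", "only" and "open" are said of these compounds alone.

Compound 2 `COc1ccc(/C=C\c2cc(OC)c(OC)c(OC)c2)cc1OCc1ccc(CN2C[C@H](O)C[C@@H]2C(=O)O)cc1` carries the 2-carboxy-4-hydroxypyrrolidin-1-yl group on the shared core. Within the data shown here, in a functional assay on HeLa cells (Homo sapiens) for antiproliferative activity, read by CCK-8 assay, with a stated time of 48 h (on this read-out lower numbers stand for stronger inhibition and higher numbers for weaker inhibition), compound 2 gives only a limit, > 10000 nM, so its standing among the three measured members is not a number (the limit of > 10000 nM in this assay, at which 1 of the 3 values shown sits). Compound 1 `COc1ccc(/C=C\c2cc(OC)c(OC)c(OC)c2)cc1OCc1ccc(CN2CC(C(=O)O)C2)cc1` gives 6500 nM in this assay, and compound 3 `COc1ccc(/C=C\c2cc(OC)c(OC)c(OC)c2)cc1OCc1ccc(CN2CC[C@@H](C(=O)O)C2)cc1` gives 12800 nM in this assay. The measured steps are an at least 1.5-fold higher number from compound 1 to compound 2 (0.18 log units; that floor lies within the scatter) and a 2.0-fold higher number from compound 1 to compound 3 (0.29 log units; within the scatter); between the two pyrrolidines there is a step that the limit leaves unreadable from compound 2 to compound 3.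

Among the measured compounds shown here, compound 4 `COc1ccc(/C=C\c2cc(OC)c(OC)c(OC)c2)cc1OCc1ccc(CN2CC[C@H](O)C2)cc1` is the unmeasured member. 3-hydroxypyrrolidin-1-yl in place of 2-carboxy-4-hydroxypyrrolidin-1-yl on a saturated chain carbon bound to an aromatic carbon None of the measured steps removes the carboxy group: each of them changes the ring size or the position of the carboxy group, and none of them reaches beyond the scatter where it can be read at all. For the measured compounds named here, the change from compound 2 to compound 4 therefore has no measured precedent, and the limit on compound 2 leaves both the size and the direction of any step open. Compound 4 is expected to land among the values of the measured compounds rather than clearly apart from them, with the step of an at least 1.4-fold lower number from compound 2 to compound 4 (0.15 log units; that floor lies within the scatter) estimated only loosely. For compound 4 the estimate in this assay is 7000 nM, within 1500 nM to 25000 nM.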

Compound 4, half-maximal inhibitory concentration: 10500 nM
Compound 4: the middle estimate sits 1.5-fold (0.18 log units) below what was measured; the measured number falls inside the stated range.
By their numbers in this assay, from the lowest: compounds 1, 4 and 3 (each within the scatter of the next).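

In this assay, compound 4 is the first member shown with no carboxy group on the ring at this place, on a saturated chain carbon bound to an aromatic carbon, and both readable steps stay within the scatter: a 1.2-fold lower number from compound 3 to compound 4 (0.09 log units; within the scatter), and a 1.6-fold higher number from compound 1 to compound 4 (0.21 log units; within the scatter). Among compounds 1, 3 and 4, the presence of a carboxy group therefore does not separate the numbers, since 3-hydroxypyrrolidin-1-yl fits within the same scatter as the 3-carboxypyrrolidin-1-yl of compound 3 and the 3-carboxyazetidin-1-yl of compound 1. Compound 2 remains a limit, so its step to compound 4 cannot be read, and the change from 2-carboxy-4-hydroxypyrrolidin-1-yl gives no size or direction: the limit of > 10000 nM in this assay, at which 1 of the 4 values shown sits.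

Going by these compounds, it remains open whether an unsubstituted pyrrolidin-1-yl, a piperidin-1-yl, a morpholin-4-yl or a dimethylamino group at this place would also stay within this scatter or move the number clearly away from it. On these data alone, the opposite stereocentre of the 3-hydroxypyrrolidin-1-yl group, and a methyl ester in place of the carboxylic acid, are likewise open.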